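The compounds below may be only part of what the source reports. "The series", "measured", "known", "first", "only" and "open" are said of these compounds alone.

Of the compounds shown here, three with a shared core have been tested in a functional assay on MDA-MB-231 cells (Homo sapiens) for inhibition, read by MTT assay, with a stated time of 72 h; on this read-out higher numbers stand for weaker inhibition and lower numbers for stronger inhibition. Compound 1 `COC(=O)c1ccc(-n2cc(CCCOC(=O)c3ccc(C)cc3)nn2)cc1` gives > 100000 nM, which is a limit of the assay and not a number. Compound 2 `COC(=O)c1ccc(-n2cc(CCCNC(=S)Nc3ccc(C)cc3)nn2)cc1` gives > 100000 nM, which is also a limit. Compound 1 thus stands at the limit of > 100000 nM in this assay, at which 2 of the 3 values shown sit, with no number to start from. Only compound 3 `COC(=O)c1ccc(-n2cc(CCCn3nnc(-c4ccc(C)cc4)n3)nn2)cc1` returns a number, at 36500 nM.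

Compound 4 `COC(=O)c1ccc(-n2cc(CCCOc3ccc(C)cc3)nn2)cc1` differs from compound 1 in one place: 4-methylphenyl in place of (4-methylphenyl)carbonyl on an oxygen on a saturated carbon. In words, it carries 4-methylphenyl in place of (4-methylphenyl)carbonyl on an oxygen on a saturated carbon. Among the compounds with values here, no measured step between two compounds is available as a guide. Only a small shift in this assay is expected, towards stronger inhibition if there is any, and compound 4 may well stay at the limit. The expected size is an at least 1.2-fold lower number from compound 1 to compound 4 (0.09 log units; that floor lies within the scatter), a rough estimate given the limit at its start. Compound 4 is estimated at 80000 nM, with an expected range from 25000 nM to 200000 nM.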

Compound 4, half-maximal inhibitory concentration: 14200 nM
Compound 4: the middle estimate sits 5.6-fold (0.75 log units) above what was measured; measured number outside the range, below it.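

In this assay, within the data shown here, putting 4-methylphenyl in place of (4-methylphenyl)carbonyl on this oxygen gives an at least 7.0-fold lower number from compound 1 to compound 4 (0.84 log units; beyond the scatter), the first step that can be read, and it shows that the group on this oxygen matters to the read-out. The aromatic ring stays and the carbonyl leaves, so the ring on the oxygen without the carbonyl is enough to give a measurable number. The step is a floor and not a full size, since compound 1 sits at a limit: the limit of > 100000 nM in this assay, at which 2 of the 4 values shown sit.

This single pair cannot tell whether losing the carbonyl itself counts or whether something else about the swap does. Also open, going by these compounds, is how an amine in place of this oxygen, or a longer chain carrying the same 4-methylphenyl, would read.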